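From Methoxyphenyl to Chlorophenyl: Little Change Expected

The compounds below may be only part of what the source reports. "The series", "measured", "known", "first", "only" and "open" are said of these compounds alone.

Compound 3 `COc1ccc(-c2cc(N3CCC(CCNS(N)(=O)=O)CC3)ncn2)cc1` gives 69800 nM in a functional assay on M21 cells (Homo sapiens) for antiproliferative activity, read by sulforhodamine B assay, with a stated time of 48 h (a lower number here means a stronger inhibitor of growth, a higher number a weaker inhibitor of growth), which places it alongside compound 2 `Cc1ccc(-c2cc(N3CCC(CCNS(N)(=O)=O)CC3)ncn2)cc1` at 57600 nM and compound 1 `NS(=O)(=O)NCC1CCN(c2cc(-c3cccc(Cl)c3)ncn2)CC1` at 62500 nM, all three within the scatter of one another. Among the compounds with values here, the only measured step among them, a 1.2-fold higher number from compound 2 to compound 3 (0.08 log units; within the scatter), was flat. Compound 4 `NS(=O)(=O)NCCC1CCN(c2cc(-c3cccc(Cl)c3)ncn2)CC1` differs from compound 3 by 3-chlorophenyl in place of 4-methoxyphenyl on an aromatic carbon. Within the data shown here, no measured step covers this exact exchange; compound 1 carries the same 3-chlorophenyl group and gives a number indistinguishable from that of compound 3, so the exchange is expected to leave the result in this assay essentially untouched. Compound 4 is therefore estimated at 62000 nM, with a range of 30000 nM to 125000 nM, corresponding to an expected 1.1-fold lower number from compound 3 to compound 4 (0.05 log units; within the scatter).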

Compound 4, concentration for 50% growth inhibition: 50700 nM
For compound 4 the middle estimate is 1.2-fold (0.09 log units) above the measured one; low and high end bracket the measured number.
By their numbers in this assay, from the lowest: compounds 4, 2, 1 and 3 (each within the scatter of the next).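

In this assay, 3-chlorophenyl in place of 4-methoxyphenyl gives a 1.4-fold lower number from compound 3 to compound 4 (0.14 log units; within the scatter) and in place of 4-methylphenyl gives a 1.1-fold lower number from compound 2 to compound 4 (0.06 log units; within the scatter) on this aromatic carbon, so the three phenyl groups cannot be told apart here. The chain behaves alike, with (sulfamoylamino)methyl in place of sulfamoylamino giving a 1.2-fold lower number from compound 1 to compound 4 (0.09 log units; within the scatter) at the saturated chain carbon. No evidence is available that bears on these steps.

The compounds shown leave open whether an amine or a carboxylic acid on the phenyl ring would move the number beyond the scatter. From the compounds shown here alone, a longer chain carrying the sulfamoylamino group remains equally open.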